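The compounds below may be only part of what the source reports. "The series", "measured", "known", "first", "only" and "open" are said of these compounds alone.

Measured compounds:
Compound 1 `CC(=O)OC/C1=C/C[C@](C)(CCC=C(C)C)/C=C/[C@@H](OC(=O)C=C(C)C)[C@](C)(O)/C=C/C1=O` — a functional assay on HL-60 cells (Homo sapiens) for antiproliferative activity, read by MTT assay, with a stated time of 48 h; on this read-out lower numbers stand for stronger inhibition and higher numbers for weaker inhibition: 2950 nM
Compound 2 `CC(C)=CCC[C@]1(C)/C=C/[C@@H](OC(=O)C=C(C)C)[C@](C)(O)/C=C/C(=O)/C(CN(C)C)=C\C1` — this assay: 140 nM
Compound 3 `CC(C)=CCC[C@]1(C)/C=C/[C@@H](OC(=O)C=C(C)C)[C@](C)(O)/C=C/C(=O)/C(CN2CCN(C)CC2)=C\C1` — this assay: 840 nM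

Among the three measured numbers, compound 3 stands second highest: its nearest neighbour is compound 1, with a 3.5-fold lower number from compound 1 to compound 3 (0.55 log units; beyond the scatter), and its furthest is compound 2, with a 6.0-fold higher number from compound 2 to compound 3 (0.78 log units; beyond the scatter). Compound 4 `CCN(CC)C(=O)/C1=C/C[C@](C)(CCC=C(C)C)/C=C/[C@@H](OC(=O)C=C(C)C)[C@](C)(O)/C=C/C1=O` is not yet measured. It differs from compound 3 by diethylcarbamoyl in place of (4-methylpiperazin-1-yl)methyl on a double-bonded ring carbon

The measured steps all concern exchanges at the same carbon, and they show that this position governs the read-out: a 21-fold lower number from compound 1 to compound 2 (1.32 log units; beyond the scatter), a 3.5-fold lower number from compound 1 to compound 3 (0.55 log units; beyond the scatter) and a 6.0-fold higher number from compound 2 to compound 3 (0.78 log units; beyond the scatter). None of them, however, places a diethylcarbamoyl group at the double-bonded ring carbon, and none removes the saturated chain carbon that links the leaving group to the ring. The steps therefore only show that a change here can reach a modest to large size in either direction; they do not fix the direction for compound 4. Compound 3 lies between compound 1 and compound 2, and compound 4 is estimated near that middle ground, at 1500 nM, with a range from 300 nM to 8000 nM, which means an expected step of a 1.8-fold higher number from compound 3 to compound 4 (0.25 log units; within the scatter).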

Compound 4, half-maximal inhibitory concentration: 9080 nM
For compound 4 the middle estimate is 6.1-fold (0.78 log units) below the measured one; the whole stated range lies below it.
By their numbers in this assay, from the lowest: compound 2; then compound 3; then compound 1; then compound 4.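

In this assay, diethylcarbamoyl on the double-bonded ring carbon gives the highest number of the four compounds, well clear of both nitrogen-bearing methyl groups (an 11-fold higher number from compound 3 to compound 4 (1.03 log units; beyond the scatter); a 65-fold higher number from compound 2 to compound 4 (1.81 log units; beyond the scatter)). Among the compounds shown here, it also passes acetoxymethyl (a 3.1-fold higher number from compound 1 to compound 4 (0.49 log units; beyond the scatter)), so this position can move the number upward from compound 1 as well as downward, whereas the earlier steps from compound 1 ran only downward. Nothing given here explains this order.

In these compounds, the saturated chain carbon and the amine nitrogen's surroundings change together, so the contribution of each to the step remains unresolved. Going by these compounds, a (diethylamino)methyl group or a dimethylcarbamoyl group on the same ring carbon would bear directly on this, and how either reads in this assay remains open.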